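A few compounds are considered here, and "the series" means these few. Any claim that something is new, unique, unknown or untested is made for them only; others in the source may bear on it.

Compound 1 `CC(C)C[C@H](NC(=O)[C@H](C)NC(=O)c1cccnc1)C(=O)N[C@@H](CCCC[N+](C)(C)C)C(=O)N[C@@H](CO)C(N)=O` in an assay on isolated protein for displacement of a labelled ligand from Chromobox protein homolog 7 (Homo sapiens), read by fluorescence polarization, with a stated time of 15 min; on this read-out higher numbers stand for weaker inhibition and lower numbers for stronger inhibition: 91000 nM
Compound 2 `CC(C)C[C@H](NC(=O)[C@H](C)NC(=O)CCc1ccccc1)C(=O)N[C@@H](CCCC[N+](C)(C)C)C(=O)N[C@@H](CO)C(N)=O` in this assay: 26000 nM
Compound 3 `CC(C)C[C@H](NC(=O)[C@H](C)NC(=O)CNC(=O)c1ccccc1)C(=O)N[C@@H](CCCC[N+](C)(C)C)C(=O)N[C@@H](CO)C(N)=O` in this assay: 58000 nM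

All three share one core and differ only in the group attached at its end. Compound 3 stands second highest of the three numbers. Its nearest neighbour is compound 1, and a 1.6-fold lower number from compound 1 to compound 3 (0.20 log units; within the scatter), a step inside the scatter. Its furthest is compound 2, with a 2.2-fold higher number from compound 2 to compound 3 (0.35 log units; beyond the scatter). The remaining step, a 3.5-fold lower number from compound 1 to compound 2 (0.54 log units; beyond the scatter), is the largest among them, yet still only modest.

Compound 4 `CC(C)C[C@H](NC(=O)[C@H](C)NC(=O)CNS(=O)(=O)c1ccc(C(=O)O)cc1)C(=O)N[C@@H](CCCC[N+](C)(C)C)C(=O)N[C@@H](CO)C(N)=O` is not yet measured. It differs from compound 3 by (4-carboxyphenyl)sulfonyl in place of benzoyl on an amine nitrogen. Within the data shown here, none of the measured steps introduces a group like the one entering here, so no step bears directly on this change. The closest comparison is the change of the group on the chain carbon, where a 2.2-fold higher number from compound 2 to compound 3 (0.35 log units; beyond the scatter), and all three steps together show that variation of this end group moves the number only modestly. Compound 4 is therefore expected to show a 1.2-fold higher number from compound 3 to compound 4 (0.08 log units; within the scatter), a step hardly beyond the scatter in either direction. Compound 4 is estimated at 70000 nM in this assay, within a range from 25000 nM to 200000 nM.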

Compound 4, half-maximal inhibitory concentration: 53000 nM
Compound 4: the middle estimate sits 1.3-fold (0.12 log units) above what was measured; low and high end bracket the measured number.
By their numbers in this assay, from the lowest: compound 2; then compounds 4, 3 and 1 (each within the scatter of the next).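

Swapping benzoyl for (4-carboxyphenyl)sulfonyl on the amine nitrogen gives a 1.1-fold lower number from compound 3 to compound 4 (0.04 log units; within the scatter) in this assay and leaves compound 3 and compound 4 indistinguishable on this read-out. Among these compounds, this is no minor swap, since the entering group brings a sulfur, more oxygens and a hydrogen-bond donor, none of which appeared among the end groups of the earlier compounds, so this position accepts a quite different set of atoms with no measurable difference in the number. Nothing available explains why the two compounds read alike.

This single step alters two things at once, the link to the amine nitrogen and the carboxylic acid on the ring, so these two parts could each matter and cancel out, or neither could matter at all. A plain phenylsulfonyl group without the carboxylic acid would separate them, and a methyl ester or an amine in place of the carboxylic acid would show whether the ring substituent has any bearing on the number.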